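From Dipropylamino to Dibutylamino on a Long Side Chain

This account rests on a few compounds, and the source may have more. Where it says the series, first, only, none or still open, it means among the compounds named here.

Of the compounds shown here, three sharing one core have been measured in a functional assay on DU-145 cells (Homo sapiens) for antiproliferative activity, read by WST assay, with a stated time of 3 days; on this read-out lower numbers stand for stronger inhibition and higher numbers for weaker inhibition. Compound 1 `CCOc1c(-c2cc(OC)c(OC)c(OC)c2)oc2ccccc2c1=O` gives 6200 nM. Compound 2 `CCCCCCCOc1c(-c2cc(OC)c(OC)c(OC)c2)oc2ccccc2c1=O` reads > 50000 nM, which is a limit of the assay and not a number. Compound 3 `CCCN(CCC)CCCCCOc1c(-c2cc(OC)c(OC)c(OC)c2)oc2ccccc2c1=O` gives 24200 nM, the higher of the two true numbers, so it stands on the weak side of this small set.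

Compound 4 `CCCCN(CCCC)CCCCCOc1c(-c2cc(OC)c(OC)c(OC)c2)oc2ccccc2c1=O` differs from compound 3 in one place: dibutylamino in place of dipropylamino on a saturated chain carbon, five bonds along the chain from an oxygen on an aromatic ring. The dibutylamino group replaces dipropylamino on a saturated chain carbon, five bonds along the chain from an oxygen on an aromatic ring.

For the measured compounds named here, no measured pair makes this exact change, so the guidance is indirect. Enlarging the side chain raised the number twice, with pentyl giving an at least 8.0-fold higher number from compound 1 to compound 2 (0.90 log units; beyond the scatter) and 3-(dipropylamino)propyl giving a 3.9-fold higher number from compound 1 to compound 3 (0.59 log units; beyond the scatter). Going the other way, dipropylamino in place of ethyl gave an at least 2.0-fold lower number from compound 2 to compound 3 (0.31 log units; beyond the scatter), a step that rests on a limit. The two added carbons in each amine arm are a small change, so only a slight rise is expected in this assay, probably within the scatter. The expected step is a 1.2-fold higher number from compound 3 to compound 4 (0.09 log units; within the scatter). For compound 4 the estimated value is 30000 nM, with an expected range from 11000 nM to 50000 nM.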

Compound 4, half-maximal inhibitory concentration: > 50000 nM
Compound 4 was reported as a limit; the forecaster's own chance of this, stated with the estimate: 25%; middle value at least 1.6-fold (0.22 log units) from the limit.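

The result for compound 4 is a limit of the assay and not a number. Even so, in this assay, placing dibutylamino in place of dipropylamino on a saturated chain carbon, five bonds along the chain from an oxygen on an aromatic ring, gives an at least 2.0-fold higher number from compound 3 to compound 4 (0.31 log units; beyond the scatter), so a change confined to the arms of the amine is enough to move the result beyond the scatter. The whole side chain, measured against the ethyl group of compound 1, gives an at least 8.0-fold higher number from compound 1 to compound 4 (0.90 log units; beyond the scatter), which leaves compound 3 as the only compound shown with an amine on this long chain that has a true number.

How far compound 2 and compound 4 lie past the limit stays unknown, and the step between them cannot be read: the limit of > 50000 nM in this assay, at which 2 of the 4 values shown sit.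

From the compounds shown here alone, it also remains open whether a smaller amine such as dimethylamino on the same chain would give a lower number than compound 3, which gives 24200 nM.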